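A Chloro Step Repeated on a Second Core

This account rests on a few compounds, and the source may have more. Where it says the series, first, only, none or still open, it means among the compounds named here.

Compound 1 `O=C(CCCCCCN1C(=O)/C(=N\O)c2ccccc21)NO` gives 1100 nM in a functional assay on ASPC1 cells (Homo sapiens) for antiproliferative activity, read by sulforhodamine B assay, with a stated time of 48 h; a lower number here means a stronger inhibitor, a higher number a weaker inhibitor. Compound 2 `O=C(CCCCCCN1C(=O)/C(=N\O)c2cc(Cl)ccc21)NO` gives 1860 nM. Compound 3 `CO/N=C1/C(=O)N(CCCCCCC(=O)NO)c2ccccc21` gives 1220 nM.

Compound 2 differs from compound 1 by chloro in place of hydrogen on an aromatic carbon, and that change made a 1.7-fold higher number from compound 1 to compound 2 (0.23 log units; within the scatter). Compound 3 has a different core from compound 1; the difference between the two cores is not broken down here. Compound 4 `CO/N=C1/C(=O)N(CCCCCCC(=O)NO)c2c(Cl)cccc21` carries the same kind of change relative to compound 3, namely (chloro in place of hydrogen on an aromatic carbon). The surroundings differ, though: in compound 2 the chloro sits meta to a fused ring and para to a fused ring, whereas in compound 4 it sits ortho to a fused ring and meta to a fused ring. A step of a 1.5-fold higher number from compound 3 to compound 4 (0.17 log units; within the scatter) is expected for compound 4, resting on the earlier step of a 1.7-fold higher number from compound 1 to compound 2 (0.23 log units; within the scatter), which stayed within the scatter. Compound 4 is therefore estimated at 1800 nM, with a likely range from 900 nM to 3600 nM.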

Compound 4, half-maximal inhibitory concentration: 630 nM
Estimate against measurement, compound 4: 2.9-fold (0.46 log units) above, outside the stated range (below it).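

In this assay, chloro in place of hydrogen on the core of compound 3 gave a 1.9-fold lower number from compound 3 to compound 4 (0.29 log units; within the scatter), which does not repeat the step seen on the core of compound 1, and the two steps differ when set side by side: the same change on two cores in this assay, a 1.7-fold higher number (0.23 log units; within the scatter) from compound 1 to compound 2 and a 1.9-fold lower number (0.29 log units; within the scatter) from compound 3 to compound 4, 3.3-fold (0.52 log units) apart, beyond the scatter of two such steps. So in this series, the size and direction of this change cannot safely be carried from one core to the other. Each step alone lies within the scatter. The chloro differs in its ring place as well as its core, and the compounds shown cannot separate these two differences.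

The compounds shown leave open whether chloro at the same ring place on both cores would give matching steps. They also leave open whether a bromo or methyl group at these places would follow chloro.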